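Ester swap on the side chain of compound 1

The source may hold more compounds than are shown below. What is called first, only, known or untested is meant among the compounds shown, and "the series" means these compounds.

Measured so far in a functional assay on A549 cells (Homo sapiens) for cytotoxicity, read by MTT assay, with a stated time of 24 h (on this read-out lower numbers stand for stronger inhibition and higher numbers for weaker inhibition), for three compounds:
- compound 1 `COC(=O)[C@H](NC(=O)Cn1cc(C2=C(c3c[nH]c4ccccc34)C(=O)N(C)C2=O)c2ccccc21)[C@@H](C)O` 25700 nM
- compound 2 `COC(=O)CCNC(=O)Cn1cc(C2=C(c3c[nH]c4ccccc34)C(=O)N(C)C2=O)c2ccccc21` 37600 nM
- compound 3 `COC(=O)[C@@H](CO)NC(=O)Cn1cc(C2=C(c3c[nH]c4ccccc34)C(=O)N(C)C2=O)c2ccccc21` 37900 nM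

Compound 1 at 25700 nM sits within the scatter of both compound 2 and compound 3, so the three cannot be ranked. The next compound is compound 4 `COC(=O)CC[C@@H](NC(=O)Cn1cc(C2=C(c3c[nH]c4ccccc34)C(=O)N(C)C2=O)c2ccccc21)C(=O)OC` which is not yet measured. It differs from compound 1 by 2-(methoxycarbonyl)ethyl in place of 1-hydroxyethyl on a saturated chain carbon bound to an amide-type nitrogen and a carbonyl carbon with 2-(methoxycarbonyl)ethyl in place of 1-hydroxyethyl on a saturated chain carbon bound to an amide-type nitrogen and a carbonyl carbon. Among the compounds with values here, no measured compound carries that group on that carbon, so the evidence is indirect. The steps available are small: a 1.5-fold higher number from compound 1 to compound 2 (0.17 log units; within the scatter) and a 1.5-fold higher number from compound 1 to compound 3 (0.17 log units; within the scatter) and a 1.0-fold higher number from compound 2 to compound 3 (0.00 log units; within the scatter) all stay within the scatter. The expected change is a 1.2-fold higher number from compound 1 to compound 4 (0.10 log units; within the scatter) and it stays within the scatter, with no firm direction. Compound 4 is estimated at 32000 nM (expected range 16000 nM to 62000 nM) in this assay pending measurement.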

Compound 4, half-maximal inhibitory concentration: 73700 nM
For compound 4 the middle estimate is 2.3-fold (0.36 log units) below the measured one; measured number above the stated range.
By their numbers in this assay, from the lowest: compounds 1, 2, 3 and 4 (each within the scatter of the next, the first and the last beyond it).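

In this assay, within the data shown here, 2-(methoxycarbonyl)ethyl in place of 1-hydroxyethyl on the saturated chain carbon bound to an amide-type nitrogen and a carbonyl carbon gives a 2.9-fold higher number from compound 1 to compound 4 (0.46 log units; beyond the scatter), the first step to pass the scatter, though only a modest one. The other two new steps, a 1.9-fold higher number from compound 3 to compound 4 (0.29 log units; within the scatter) and a 2.0-fold higher number from compound 2 to compound 4 (0.29 log units; within the scatter), stay within the scatter, so at this position only compound 1 and compound 4 can be set apart. Nothing on hand accounts for the step.

Going by these compounds, whether the step follows the loss of the hydroxy or the entry of the methyl ester remains open. A plain propyl chain or a 2-carboxyethyl group on that carbon would separate the two, and would show whether this position tolerates anything beyond the groups compared here.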